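Chloro to Fluoro on a Shared Core

A few compounds are considered here, and "the series" means these few. Any claim that something is new, unique, unknown or untested is made for them only; others in the source may bear on it.

Compound 1 `Cc1nc(N(C)c2ccc([Se]C#N)c(Cl)c2)c2ccccc2n1`: 9 nM
Compound 2 `COc1ccc(N(C)c2nc(C)nc3ccccc23)cc1C(=O)NCC[Se]C#N`: 1250 nM

Both were tested in a functional assay on MDA-MB-231 cells (Homo sapiens) for inhibition, read by MTT assay, with a stated time of 48 h; a lower number here means a stronger inhibitor, a higher number a weaker inhibitor. Compound 1 stands lowest of the two numbers; compound 2 sits far above it, a gap well beyond the usual scatter. Compound 3 `Cc1nc(N(C)c2ccc([Se]C#N)c(F)c2)c2ccccc2n1` has not yet been measured. It differs from compound 1 in one place: fluoro in place of chloro on an aromatic carbon. For the measured compounds named here, no pair of measured compounds differs in only one place, so no step of this kind is known. Compound 3 is expected to land close to compound 1, perhaps slightly weaker. For compound 3 the expected value is 20 nM, within 6 nM to 70 nM. The implied step is expected to be a 2.2-fold higher number from compound 1 to compound 3 (0.35 log units; beyond the scatter).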

Compound 3, half-maximal inhibitory concentration: 6 nM
Compound 3: the middle estimate sits 3.3-fold (0.52 log units) above what was measured, and the stated range covers the measured number.
By their numbers in this assay, from the lowest: compounds 3 and 1 (each within the scatter of the next); then compound 2.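

In this assay, fluoro in place of chloro on this aromatic carbon gives a 1.5-fold lower number from compound 1 to compound 3 (0.18 log units; within the scatter), so the two compounds cannot be told apart. For the compounds shown here, this is the first one-place change seen at this position, and it shows that the low number survives this swap of one single-atom group for another. No measurement shown explains why the two compounds read alike. Still open, going by these compounds, is how this carbon would respond to a larger or quite different group, such as an amine or a methyl group, since only chloro and fluoro appear here.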